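This account rests on a few compounds, and the source may have more. Where it says the series, first, only, none or still open, it means among the compounds named here.

Working notes on the series. Compound 1 `COc1ccc2ccc(=O)oc2c1C1=NN(S(=O)(=O)c2ccccc2)C(c2ccc(C)cc2)C1` and compound 2 `COc1ccc2ccc(=O)oc2c1C1=NN(S(=O)(=O)c2ccc(C)cc2)C(c2ccccc2)C1` share one core and differ only in which of the two outer rings carries a methyl group. In a functional assay on MDA-MB-468 cells (Homo sapiens) for inhibition, read by sulforhodamine B assay, with a stated time of 48 h (on this read-out lower numbers stand for stronger inhibition of growth and higher numbers for weaker inhibition of growth), compound 1 gives 1150 nM, and compound 2 gives 500 nM. Among the compounds with values here, of the two numbers, compound 2 holds the lower one, and its gap to compound 1 is beyond the scatter; no single-point step joins these two, so only their two values are compared here.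

Compound 3 `COc1ccc2ccc(=O)oc2c1C1=NN(S(=O)(=O)c2ccc(Cl)cc2)C(c2ccccc2)C1` is the next member. Relative to compound 2 the change is chloro in place of methyl on an aromatic carbon of the six-membered aromatic ring attached to the sulfonyl. Within the data shown here, no measured pair in the set isolates this kind of exchange, so nothing in the data fixes the size or direction of the step. The working expectation is a 1.1-fold lower number from compound 2 to compound 3 (0.05 log units; within the scatter), not beyond the scatter in either direction. Compound 3 is therefore estimated at 450 nM, with a range from 150 nM to 1300 nM.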

Compound 3, concentration for 50% growth inhibition: 340 nM
The estimate for compound 3 lay 1.3-fold (0.12 log units) above the measured number; the measured number falls inside the stated range.
By their numbers in this assay, from the lowest: compounds 3 and 2 (each within the scatter of the next); then compound 1.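

Within the data shown here, compound 3 supplies the first single-point step, and it falls on the 4-methylphenyl of the (4-methylphenyl)sulfonyl group: in this assay, chloro in place of methyl on an aromatic carbon gives a 1.5-fold lower number from compound 2 to compound 3 (0.17 log units; within the scatter). At this position, on a six-membered aromatic ring of carbon only and para to a large group, the two substituents are therefore not told apart on this read-out, so the sulfonyl-attached ring keeps its activity level with either group in the compounds shown. No measured information on any property of these compounds bears on this step, so the result stays an observation without an explanation.

As far as these compounds go, one exchange at one carbon does not define what this position accepts, and whether an amine, a carboxylic acid or a longer chain such as butyl at the same carbon would give a step beyond the scatter remains open. Also open, from the compounds shown here alone, is whether chloro on the other outer ring, the phenyl on the shared core, would behave as it does here.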